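Methyl for Methoxy on a Lactone Core: Predicting Compound 4

This account rests on a few compounds, and the source may have more. Where it says the series, first, only, none or still open, it means among the compounds named here.

Compounds measured in a functional assay on HL-60 cells (Homo sapiens) for cytotoxicity, read by WST assay, with a stated time of 48 h; a lower number here means that less compound is needed, a higher number that more compound is needed for the effect:
compound 1, `COc1ccc(C[C@H]2C(=O)OC[C@@H]2Cc2ccccc2)cc1`, gives 67000 nM;
compound 2, `Cc1ccc(C[C@H]2C(=O)OC[C@@H]2Cc2ccccc2)cc1`, gives 44000 nM;
compound 3, `COc1cccc(C[C@H]2COC(=O)[C@@H]2Cc2ccc(Cl)c(Cl)c2)c1`, gives 34000 nM.

Compound 1 and compound 2 differ by one change, (methyl in place of methoxy on an aromatic carbon), which gave a 1.5-fold lower number from compound 1 to compound 2 (0.18 log units; within the scatter). The difference between the core of compound 1 and the core of compound 3 is not broken down here; the three values all lie within the scatter of one another.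

Compound 4, `Cc1cccc(C[C@H]2COC(=O)[C@@H]2Cc2ccc(Cl)c(Cl)c2)c1`, is not yet measured. It differs from compound 3 by methyl in place of methoxy on an aromatic carbon, the same kind of change as before, though here the group sits meta to a large group rather than para to it. Because compound 1 to compound 2 gave a 1.5-fold lower number from compound 1 to compound 2 (0.18 log units; within the scatter), a step of similar size, a 1.3-fold lower number from compound 3 to compound 4 (0.12 log units; within the scatter), is expected in this assay. Compound 4 is therefore estimated at 26000 nM, with a likely range from 12000 nM to 55000 nM.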

Compound 4, half-maximal effective concentration: 22000 nM
Compound 4: the middle estimate sits 1.2-fold (0.07 log units) above what was measured; the range from low to high includes it.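

In this assay, methyl in place of methoxy gave a 1.5-fold lower number from compound 3 to compound 4 (0.19 log units; within the scatter), and the same change on the core of compound 1 gave a matching result: the same change on two cores in this assay, a 1.5-fold lower number (0.18 log units; within the scatter) from compound 1 to compound 2 and a 1.5-fold lower number (0.19 log units; within the scatter) from compound 3 to compound 4, 1.0-fold (0.01 log units) apart, within the scatter of two such steps.
The change therefore carried over from one core to the other with a step of about the same size, at least for these two pairs. Each step lies within the scatter, however, so neither shows that the change has a real effect on the number, and two pairs say nothing about further cores.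

The compounds shown leave open what other groups would do in this place on the aromatic ring, such as an amine, a carboxylic acid or a longer chain. They also leave open what lies behind the matching steps.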